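Imidazole Joined Through Carbon Rather Than Nitrogen

The source may hold more compounds than are shown below. What is called first, only, known or untested is meant among the compounds shown, and "the series" means these compounds.

The measured compounds:
compound 1, `CC(CC(=O)/N=C(\N)NCCCc1cccnc1)c1ccccc1`, 5.27
compound 2, `CC(CC(=O)/N=C(\N)NCCCc1ccc(CN(C)C)o1)c1ccccc1`, 6.52
compound 3, `CC(CC(=O)/N=C(\N)NCCCn1ccnc1)c1ccccc1`, reported only as the limit < 5

In a functional assay on Sf9 cells for antagonist activity at histamine H2 receptor (Homo sapiens), with stated times of 2 min and 20 min (a higher number here means a more potent compound, by a factor of ten per unit of this negative logarithm, a lower number a less potent compound), compound 1 gives 5.27. In this assay compound 2 gives 6.52. Compound 3 gives no number in this assay; it is recorded only as a limit, < 5. The steps among the three show a number 1.25 log units higher from compound 1 to compound 2 (beyond the scatter), a number at least 0.27 log units lower from compound 1 to compound 3 (that floor lies within the scatter) and a number at least 1.52 log units lower from compound 2 to compound 3 (beyond the scatter). Within the data shown here, compound 3 thus stands at the floor of what this assay reports, and it is the one compound among the three that sits there (the limit of < 5 in this assay, at which 1 of the 3 values shown sits).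

Compound 4, `CC(CC(=O)/N=C(\N)NCCCc1ncc[nH]1)c1ccccc1`, has not yet been measured. It differs from compound 3 in one place: 1H-imidazol-2-yl in place of 1H-imidazol-1-yl on a saturated chain carbon, three bonds along the chain from an amine nitrogen. Among the measured compounds shown here, no measured step here touches a 1H-imidazol-2-yl ring, so the expectation for compound 4 rests only on the two steps that end at compound 3, both of which lead down to the limit. Compound 4 is therefore expected to land near that floor, with a modest rise as the most likely outcome: an estimated 5.3, ranging from 4.6 to 6. The expected step from compound 3 is a number at least 0.30 log units higher from compound 3 to compound 4 (that floor lies within the scatter), and a report of only a limit again remains a real possibility.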

Compound 4, negative logarithm of the antagonist equilibrium constant: 5.3
Estimate against measurement, compound 4: no gap at the digits printed; the measured number falls inside the stated range.
By their numbers in this assay, from the lowest: compounds 1 and 4 (each within the scatter of the next); then compound 2. At a limit, below all of these: compound 3.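

Joining the imidazole through carbon rather than through nitrogen, on a saturated chain carbon, three bonds along the chain from an amine nitrogen, gives a measurable number in this assay, and the step reads a number at least 0.30 log units higher from compound 3 to compound 4 (that floor lies within the scatter). Compound 3 is still recorded only as a limit, not a number: the limit of < 5 in this assay, at which 1 of the 4 values shown sits. The 1H-imidazol-2-yl ring also shows no separation from the pyridin-3-yl ring, with a number 0.03 log units higher from compound 1 to compound 4 (within the scatter), while the 5-((dimethylamino)methyl)furan-2-yl ring keeps a clear lead, with a number 1.22 log units lower from compound 2 to compound 4 (beyond the scatter).

Going by these compounds, the true size of the change from 1H-imidazol-1-yl to 1H-imidazol-2-yl stays open, as does how much of it, if any, goes with the hydrogen-bond donor that only the second ring carries. Also open, on these data alone, is whether a dimethylamino group carried on the 1H-imidazol-2-yl ring through a methylene, as it is on the furan of compound 2, or a longer chain leading to that ring would close the gap to compound 2.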